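This account rests on a few compounds, and the source may have more. Where it says the series, first, only, none or still open, it means among the compounds named here.

In a physicochemical assay for solubility, in phosphate buffer, at pH 6.8 (on this read-out higher numbers stand for higher solubility and lower numbers for lower solubility), compound 1 (`CCNc1nc2ccsc2c(=O)n1CC`) gives 240 ug/mL, the higher of the two numbers available. Compound 2 (`CCn1c(NC(C)C)nc2c(-c3ccco3)csc2c1=O`) gives 0.1 ug/mL, far lower and well beyond the scatter. Compound 3 (`CCCNc1nc2ccsc2c(=O)n1CC`) keeps the core of compound 1 but carries propylamino in place of ethylamino: methyl in place of hydrogen on a saturated chain carbon, two bonds along the chain from a nitrogen on an aromatic ring. Among the compounds with values here, no measured pair shows a change of this kind, so this is a cautious judgement: a modest fall in this assay is expected, of a size close to the usual scatter. The estimated step is a 2.2-fold lower number from compound 1 to compound 3 (0.34 log units; beyond the scatter). Compound 3 is expected at 110 ug/mL, with an estimated range of 35 ug/mL to 280 ug/mL.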

Compound 3, solubility: 69 ug/mL
For compound 3 the middle estimate is 1.6-fold (0.20 log units) above the measured one; the measured number falls inside the stated range.
By their numbers in this assay, from the lowest: compound 2; then compound 3; then compound 1.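

Going from ethylamino to propylamino gives the first measured step at this position: in this assay there is a 3.5-fold lower number from compound 1 to compound 3 (0.54 log units; beyond the scatter) and this lies beyond the usual scatter. A single added methyl on this saturated chain is therefore enough to move the number on the core of compound 1. Nothing available explains this fall.

On these data alone, whether a longer chain such as butylamino would lower the number further remains open. So does the outcome with an amine or a carboxylic acid on this chain.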